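Acylamino core series: alkyl on the five-membered ring

The source may report more compounds than this note shows. Statements on the series, on what has been measured and on what is new or still open speak of the compounds shown alone.

Of the compounds shown here, three have been measured in an assay on cells for inhibition of cytochrome P450 11B2, mitochondrial (Homo sapiens), read by HTRF; a lower number here means a stronger inhibitor, a higher number a weaker inhibitor. Compound 1 `CC(=O)N[C@@H]1CCCc2c1cncc2N1Cc2cc(Cl)ccc2C1=O` gives 44 nM. Compound 2 `CCC(=O)N[C@@H]1CCCc2c1cncc2N1Cc2cc(Cl)ccc2C1=O` gives 28 nM. Compound 3 `CCC(=O)N[C@@H]1CCCc2c1cncc2N1C(=O)c2ccc(Cl)cc2[C@H]1CC` gives 90 nM.

Two single changes connect these. From compound 2 to compound 1 the change is hydrogen in place of methyl on a saturated chain carbon bound to a carbonyl carbon, and the step is a 1.6-fold higher number from compound 2 to compound 1 (0.20 log units; within the scatter). From compound 2 to compound 3 the change is ethyl in place of hydrogen on a saturated ring carbon, and the step is a 3.2-fold higher number from compound 2 to compound 3 (0.51 log units; beyond the scatter); compound 3 stands highest of the three, with compound 1 nearest and compound 2 furthest.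

Compound 4 `CCC(=O)N[C@@H]1CCCc2c1cncc2N1C(=O)c2ccc(Cl)cc2[C@H]1C` has not been measured in this assay. It differs from compound 3 by hydrogen in place of methyl on a saturated chain carbon bound to a saturated ring carbon. This is the same kind of change as that from compound 2 to compound 1, but at a different place: there on a saturated chain carbon bound to a carbonyl carbon, here on a saturated chain carbon bound to a saturated ring carbon. The earlier step lay within the scatter. For compound 4 the step from compound 3 is expected to be a 1.6-fold lower number from compound 3 to compound 4 (0.21 log units; within the scatter), resting on compound 3 sitting beyond compound 2 due to a 3.2-fold higher number from compound 2 to compound 3 (0.51 log units; beyond the scatter), so that shortening the chain on that ring carbon is expected to move the number back part of the way. In this assay compound 4 is estimated at 55 nM, within 25 nM to 120 nM.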

Compound 4, half-maximal inhibitory concentration: 66 nM
Beside the measured number, compound 4's estimate is 1.2-fold (0.08 log units) below it, and the stated range covers the measured number.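

Working notes on the methyl-to-hydrogen change: in this assay the new pair gives a 1.4-fold lower number from compound 3 to compound 4 (0.13 log units; within the scatter), and this step, with a change of the same kind on the other core, stays small on both, with no difference between them that can be read: the same change on two cores in this assay, a 1.6-fold higher number (0.20 log units; within the scatter) from compound 2 to compound 1 and a 1.4-fold lower number (0.13 log units; within the scatter) from compound 3 to compound 4, 2.1-fold (0.33 log units) apart, within the scatter of two such steps. Among the compounds shown here, this shows only that the change had no effect beyond the scatter in either of these two pairs, and so gives no sign that its outcome depends on the core. For the compounds shown here, it does not establish a shared direction or a transferable size, since both steps lie within the scatter, there are only two pairs, and the change sits at a different place in each: on a saturated chain carbon bound to a carbonyl carbon in one, and on a saturated chain carbon bound to a saturated ring carbon in the other.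

The steps beyond the scatter in this set come with alkyl on the saturated ring carbon, a 2.4-fold higher number from compound 2 to compound 4 (0.37 log units; beyond the scatter) and a 3.2-fold higher number from compound 2 to compound 3 (0.51 log units; beyond the scatter), and whether these methyl and ethyl compounds truly differ from each other remains unresolved. Still open, from the compounds shown here alone, is how a longer chain such as propyl, a cyclopropyl ring, a hydroxyl or an amine on that ring carbon would read in this assay.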